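Swapping the benzyl substituent in a triazole amide series

The source may hold more compounds than are shown below. What is called first, only, known or untested is meant among the compounds shown, and "the series" means these compounds.

Measured so far:
Compound 1, `COc1cc(Cn2cc(CNC(=O)c3cn(-c4ccccc4)nc3-c3ccc(F)cc3)nn2)cc(OC)c1`, gives 2500 nM in a functional assay on MCF7 cells (Homo sapiens) for antiproliferative activity, read by sulforhodamine B assay, with a stated time of 48 h; on this read-out higher numbers stand for weaker inhibition of growth and lower numbers for stronger inhibition of growth.
Compound 2, `O=C(NCc1cn(Cc2ccc(C(F)(F)F)cc2)nn1)c1cn(-c2ccccc2)nc1-c1ccc(Cl)cc1`, gives 4900 nM in this assay.

Among the measured compounds shown here, of the two numbers, compound 2 has the higher one, and its only neighbour is compound 1, whose number is lower by an amount that stays within the usual scatter of this assay, so the two cannot be ranked against each other.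

Compound 3, `COc1cc(Cn2cc(CNC(=O)c3cn(-c4ccccc4)nc3-c3ccc(Cl)cc3)nn2)cc(OC)c1`, is the next compound to be tested. It differs from compound 2 in one place: 3,5-dimethoxyphenyl in place of 4-(trifluoromethyl)phenyl on a saturated chain carbon bound to an aromatic nitrogen. Compound 1 already carries the 3,5-dimethoxyphenyl group at the same place, so its value of 2500 nM is the closest guide to what compound 3 might give.

For compound 3 a small downward step is expected in this assay, around a 1.6-fold lower number from compound 2 to compound 3 (0.21 log units; within the scatter), because compound 1 gives 2500 nM with the same entering group. The estimate for compound 3 is therefore 3000 nM, expected to fall between 1200 nM and 7500 nM.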

Compound 3, concentration for 50% growth inhibition: 150 nM
The estimate for compound 3 lay 20-fold (1.30 log units) above the measured number; measured number outside the range, below it.
By their numbers in this assay, from the lowest: compound 3; then compounds 1 and 2 (each within the scatter of the next).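

In this assay, replacing the 4-(trifluoromethyl)benzyl group with 3,5-dimethoxybenzyl while keeping the chloro group gives a 33-fold lower number from compound 2 to compound 3 (1.51 log units; beyond the scatter), which shows that the benzyl group on the triazole strongly affects the result; compound 1 and compound 2 differ in more than one place, so their pairing could not show this. With the 3,5-dimethoxybenzyl group held constant, chloro in place of fluoro on an aromatic carbon gives a 17-fold lower number from compound 1 to compound 3 (1.22 log units; beyond the scatter), so this small swap also has a large effect on growth inhibition. Nothing in the data explains why either change has such an effect.

The compounds shown leave open whether chloro in place of fluoro has a similar effect when the 4-(trifluoromethyl)benzyl group is present. They also leave open how a benzyl group carrying a single methoxy group, an amine or a carboxylic acid would behave at this place.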